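The source may hold more compounds than are shown below. What is called first, only, known or untested is meant among the compounds shown, and "the series" means these compounds.

Measured so far in a functional assay on HepG2 cells (Homo sapiens) for cytotoxicity, read by MTT assay, with a stated time of 24 h; on this read-out higher numbers stand for weaker inhibition and lower numbers for stronger inhibition:

- compound 1 `COc1cc(/C=C2\CN(C)C/C(=C\c3ccc(Cl)cc3)C2=O)cc(OC)c1` gives 5950 nM
- compound 2 `COc1cc(/C=C2\CN(C)C/C(=C\c3ccc(Br)cc3)C2=O)cc(OC)c1` gives 4840 nM
- compound 3 `COc1cc(/C=C2\CN(C)C/C(=C\c3ccc(Cl)c(Cl)c3)C2=O)cc(OC)c1` gives 3840 nM

The steps of a 1.3-fold lower number from compound 2 to compound 3 (0.10 log units; within the scatter) and a 1.5-fold lower number from compound 1 to compound 3 (0.19 log units; within the scatter) both stay within the scatter, so compound 3 at 3840 nM cannot be told apart from the other two. Compound 4 `COc1cc(/C=C2\CN(C)C/C(=C\c3ccc(C#N)cc3)C2=O)cc(OC)c1` carries 4-cyanophenyl in place of 3,4-dichlorophenyl on a double-bonded chain carbon bound to a double-bonded ring carbon, with 4-cyanophenyl in place of 3,4-dichlorophenyl on a double-bonded chain carbon bound to a double-bonded ring carbon as the counted difference. Going by the values given here, no measured compound carries a nitrile, so the only guides are those two steps and the halogen swap a 1.2-fold lower number from compound 1 to compound 2 (0.09 log units; within the scatter), all small. No step beyond the scatter is therefore expected in this assay for this change. An estimated 1.2-fold higher number from compound 3 to compound 4 (0.07 log units; within the scatter) is expected. For compound 4 the estimate is 4500 nM with an expected range between 2000 nM and 9000 nM overall.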

Compound 4, half-maximal inhibitory concentration: 880 nM
The estimate for compound 4 lay 5.1-fold (0.71 log units) above the measured number, and the stated range ends above it.
By their numbers in this assay, from the lowest: compound 4; then compounds 3, 2 and 1 (each within the scatter of the next).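

In this assay the group on this double-bonded chain carbon now makes a difference beyond the scatter: 4-cyanophenyl gives a 4.4-fold lower number from compound 3 to compound 4 (0.64 log units; beyond the scatter) and the swaps on the aromatic carbon give a 5.5-fold lower number from compound 2 to compound 4 (0.74 log units; beyond the scatter) and a 6.8-fold lower number from compound 1 to compound 4 (0.83 log units; beyond the scatter) as well. The halogen-bearing compounds stayed within the scatter of one another, whereas the nitrile sets compound 4 apart from all three. Nothing available here bears on why this change lowers the number.

On these data alone, whether this is special to the nitrile remains open. An amine or a carboxylic acid in its place could give a similar number or a very different one.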